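The source may hold more compounds than are shown below. What is called first, only, known or untested is meant among the compounds shown, and "the series" means these compounds.

Among the measured compounds shown here, in a functional assay on K562 cells (Homo sapiens) for antiproliferative activity, read by MTT assay, with a stated time of 48 h (on this read-out lower numbers stand for stronger inhibition and higher numbers for weaker inhibition), compound 3 `Cn1cc(C2=C(c3nn(CCCN4CCCCC4)c4ncccc34)C(=O)NC2=O)c2ccccc21` gives 5960 nM, the lowest of the three numbers measured so far. The other two are compound 1 `Cn1cc(C2=C(c3nn(CCCn4ccnc4)c4ncccc34)C(=O)NC2=O)c2ccccc21` at 13800 nM and compound 2 `CN1CCN(CCCn2nc(C3=C(c4cn(C)c5ccccc45)C(=O)NC3=O)c3cccnc32)CC1` at 46700 nM. Compound 4 `Cn1cc(C2=C(c3nn(CCCO)c4ncccc34)C(=O)NC2=O)c2ccccc21` keeps the shared core and the propyl chain of compound 3 but carries hydroxy in place of piperidin-1-yl, on a saturated chain carbon, three bonds along the chain from an aromatic nitrogen: hydroxy in place of piperidin-1-yl on a saturated chain carbon, three bonds along the chain from an aromatic nitrogen.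

The measured steps that bear on this change all alter the same chain end: a 2.3-fold lower number from compound 1 to compound 3 (0.36 log units; beyond the scatter), a 7.8-fold lower number from compound 2 to compound 3 (0.89 log units; beyond the scatter) and a 3.4-fold higher number from compound 1 to compound 2 (0.53 log units; beyond the scatter). For the measured compounds named here, each is modest, though beyond the scatter, and none involves hydroxy, so the data give no direct precedent for it. Compound 3 at 5960 nM lies lowest with piperidin-1-yl, and both other chain ends give higher numbers, so a modest rise is expected in this assay. The expected change is a 2.3-fold higher number from compound 3 to compound 4 (0.37 log units; beyond the scatter). For compound 4 the estimated value is 14000 nM, with an expected range from 4500 nM to 45000 nM.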

Compound 4, half-maximal inhibitory concentration: 85800 nM
Compound 4: the middle estimate sits 6.1-fold (0.79 log units) below what was measured; the measured number lies above the stated range.
By their numbers in this assay, from the lowest: compound 3; then compound 1; then compounds 2 and 4 (each within the scatter of the next).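

In this assay, hydroxy at the end of the propyl chain gives a 14-fold higher number from compound 3 to compound 4 (1.16 log units; beyond the scatter), the only large step at this position so far, and a 6.2-fold higher number from compound 1 to compound 4 (0.79 log units; beyond the scatter), so the chain end can move the number further than the swaps among the three ring-bearing ends had shown. Against 4-methylpiperazin-1-yl, hydroxy gives a 1.8-fold higher number from compound 2 to compound 4 (0.26 log units; within the scatter), so these two ends cannot be told apart here, and compound 2 goes against any reading that a ring at the chain end by itself keeps the number low. Nothing measured here accounts for these differences.

The compounds shown leave open whether a dimethylamino group, a carboxylic acid or a methoxy group at this chain end would read like compound 3 or like compound 4. They also leave open how a longer chain carrying piperidin-1-yl would compare with compound 3 in this assay.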